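Working notes: from compound 3 to compound 4

The compounds below may be only part of what the source reports. "The series", "measured", "known", "first", "only" and "open" are said of these compounds alone.

Results so far in an ADME assay on MDCK cells (Canis lupus familiaris) for permeability, in the apical to basolateral direction; on this read-out lower numbers stand for lower permeability and higher numbers for higher permeability
- compound 1 `CC(C)C(c1ccc(-c2ccc3cccc(F)c3c2)[nH]c1=O)C1NC(=O)NC1=O` gives "not determined" (no result reported)
- compound 2 `CC(C)C(CC1NC(=O)NC1=O)c1ccc(-c2ccc3cccc(F)c3c2)[nH]c1=O` gives 17.1 10^-6 cm/s
- compound 3 `CC(C)C(c1ccc(-c2ccc3cccc(F)c3c2)[nH]c1=O)C1C(=O)NC(=O)N1C` gives "not determined" (no result reported)

Compound 3 has no number on this read-out, so it cannot be placed against the rest of the series. Among the measured compounds shown here, compound 1 shares that gap, which leaves compound 2 as the only compound with a measured permeability.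

The next compound to be measured is compound 4 `CC(C)C(/C=C1/C(=O)NC(=O)N1C)c1ccc(-c2ccc3cccc(F)c3c2)[nH]c1=O`, which keeps the shared core and changes one group relative to compound 3. The change is a group of 9 heavy atoms (5 carbon, 2 nitrogen, 2 oxygen; one five-membered non-aromatic ring with 2 hetero atoms) in place of a group of 8 heavy atoms (4 carbon, 2 nitrogen, 2 oxygen; one five-membered non-aromatic ring with 2 hetero atoms), on a saturated chain carbon bound to an aromatic carbon and a saturated chain carbon and it is the only difference between the two structures.

For the measured compounds named here, no step between measured compounds is available to size this change, and compound 3 offers no starting value. Going by the values given here, the expectation in this assay is therefore a result within the usual scatter of the sole measured value, with no direction favoured. Compound 2 at 17.1 10^-6 cm/s is the only anchor, so the range is kept wide. The estimate for compound 4 is 15 10^-6 cm/s, and the measurement is expected to fall from 6 10^-6 cm/s to 32 10^-6 cm/s when it is reported.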

Compound 4, apparent permeability: 14.1 10^-6 cm/s
Estimate against measurement, compound 4: 1.1-fold (0.03 log units) above, within the range that was stated.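

In this assay, among the compounds shown here, a 1.2-fold lower number from compound 2 to compound 4 (0.08 log units; within the scatter) and lies within the usual scatter, giving the first pair of measured values for groups on a saturated chain carbon bound to an aromatic carbon and a saturated chain carbon. Both groups contain one five-membered non-aromatic ring with 2 hetero atoms, and the exchange of a group of 8 heavy atoms for one of 9 heavy atoms leaves the two compounds indistinguishable on this read-out. No measurement available here accounts for this result.

On these data alone, whether the 3-methyl-2,5-dioxoimidazolidin-4-yl group reads like the groups of compound 2 and compound 4 stays open, since compound 3 gives "not determined" (no result reported). The compounds shown also leave open how this assay responds when a group without this ring type stands at this place, such as an amine, a carboxylic acid or a longer chain.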